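Moving the hydroxyl around the ring in a pyridine series

The source may hold more compounds than are shown below. What is called first, only, known or untested is meant among the compounds shown, and "the series" means these compounds.

In a functional assay on T47D cells (Homo sapiens) for cytotoxicity, read by CCK-8 assay and cell counting, with a stated time of 2 days (a lower number here means a stronger inhibitor, a higher number a weaker inhibitor), compound 3 `Oc1cccc(-c2cc(-c3cccc(Cl)c3)nc(-c3cccs3)c2)c1` gives 3410 nM, the lowest number among the three measured compounds. Compound 2 `Oc1cccc(-c2cc(-c3ccc(Cl)cc3)nc(-c3cccs3)c2)c1` gives 10500 nM, and compound 1 `Oc1ccc(-c2cc(-c3cccc(Cl)c3)nc(-c3ccccn3)c2)cc1` gives 27900 nM. For the measured compounds named here, the only single-point step, a 3.1-fold lower number from compound 2 to compound 3 (0.49 log units; beyond the scatter), moved the chlorine. Compound 4 `Oc1ccc(-c2cc(-c3cccc(Cl)c3)nc(-c3cccs3)c2)cc1` differs from compound 3 by 4-hydroxyphenyl in place of 3-hydroxyphenyl on an aromatic carbon. Going by the values given here, no measured step isolates this hydroxyl move; compound 1 carries the 4-hydroxyphenyl but also differs from compound 3 in a second place, so its higher number only hints that the change may cost potency. Compound 4 is therefore expected to be somewhat weaker, with a 2.1-fold higher number from compound 3 to compound 4 (0.31 log units; beyond the scatter), and its estimated value in this assay is 7000 nM, within a range of 2500 nM to 20000 nM.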

Compound 4, half-maximal inhibitory concentration: 5350 nM
Compound 4: the middle estimate sits 1.3-fold (0.12 log units) above what was measured; measured number inside the range.
By their numbers in this assay, from the lowest: compounds 3, 4 and 2 (each within the scatter of the next, the first and the last beyond it); then compound 1.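

In this assay the change from 3-hydroxyphenyl to 4-hydroxyphenyl gives a small step (a 1.6-fold higher number from compound 3 to compound 4 (0.20 log units; within the scatter)), so this pair cannot separate the two hydroxyl placements. The ring change can now be read on its own: thiophen-2-yl in place of pyridin-2-yl gives a clearer step (a 5.2-fold lower number from compound 1 to compound 4 (0.72 log units; beyond the scatter)), which shows that this ring matters more here than the hydroxyl placement. No measurement here explains either step. The compounds shown leave open whether the hydroxyl is needed at all, and how a methoxy group or an amine in its place would behave.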